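Pyridin-3-yl to Pyridin-4-yl: Growth Inhibition Compared

The source may report more compounds than this note shows. Statements on the series, on what has been measured and on what is new or still open speak of the compounds shown alone.

The measured compounds: compound 1 `CS(=O)(=O)c1ccc(-c2cnc3[nH]cc(-c4nnc(-c5ccncc5)o4)c(=O)c3c2)cc1` gives 2.64% in a functional assay on HCT-116 cells (Homo sapiens) for inhibition, read by MTT assay, with a stated time of 24 h, tested at 2.5 uM; a higher number here means more inhibition of growth at the concentration tested, a lower number less inhibition of growth; compound 2 `O=c1c(-c2nnc(-c3ccc(F)cc3)o2)c[nH]c2ncc(-c3cccnc3)cc12` gives 9.87%; compound 3 `CS(=O)(=O)c1ccc(-c2cnc3[nH]cc(-c4nnc(-c5cccnc5)o4)c(=O)c3c2)cc1` gives 4.32%.

All three numbers lie within the scatter of one another, so none can be set above the others. From compound 3 to compound 1 the change is pyridin-4-yl in place of pyridin-3-yl on an aromatic carbon, and the step is a number 1.7 percentage points lower from compound 3 to compound 1 (within the scatter). Compound 2 and compound 3 differ in more than one place, and the difference between the two cores is not broken down here.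

Compound 4 `O=c1c(-c2nnc(-c3ccc(F)cc3)o2)c[nH]c2ncc(-c3ccncc3)cc12` is to be measured in this assay. It is made from compound 2 by pyridin-4-yl in place of pyridin-3-yl on an aromatic carbon. This is the same kind of change as from compound 3 to compound 1, not the same: there the place is on a five-membered aromatic ring with two nitrogens and one oxygen, here it is on a six-membered aromatic ring with one nitrogen in a fused system, meta to a fused ring and para to a fused ring.

The expected step from compound 2 to compound 4 is a number 1.9 percentage points lower from compound 2 to compound 4 (within the scatter), small, because the earlier step of a number 1.7 percentage points lower from compound 3 to compound 1 (within the scatter) stayed within the scatter. Compound 4 is therefore estimated at 8%, between -2% and 18%.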

Compound 4, percent growth inhibition at one concentration: 7.54%
Estimate against measurement, compound 4: 0.5 percentage points above; measured number inside the range.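

In this assay, putting pyridin-4-yl in place of pyridin-3-yl on the second core gives a number 2.3 percentage points lower from compound 2 to compound 4 (within the scatter), and the change reads alike on both cores: the same change on two cores in this assay, a number 1.7 percentage points lower (within the scatter) from compound 3 to compound 1 and a number 2.3 percentage points lower (within the scatter) from compound 2 to compound 4, 0.7 percentage points apart, within the scatter of two such steps. Within these four compounds, then, the change carries from one core to the other without producing a step that can be told from the scatter. Among these compounds, this does not show that the change is without effect in general, since neither step can be told from no change, and the comparison rests on only two cores in one assay at a single concentration.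

The compounds shown leave open how pyridin-2-yl would read at the same place on an aromatic carbon, and whether an amine or a carboxylic acid on the pyridine ring would give a number set apart from these. They also leave open what each separate difference between the two cores contributes, as no pair shown isolates one.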